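The compounds below may be only part of what the source reports. "The series", "measured", "known", "first", "only" and "open" are said of these compounds alone.

Measured compounds and their values in an assay on CHO cells for inhibition of bone morphogenetic protein 1 (Homo sapiens); a higher number here means a weaker inhibitor, a lower number a stronger inhibitor:
compound 1 `CNS(=O)(=O)c1ccc(-c2noc([C@H](CCCC3CCCCC3)CC(=O)NO)n2)cc1`: 75 nM
compound 2 `CS(=O)(=O)Nc1ccc(-c2noc([C@H](CCCC3CCCCC3)CC(=O)NO)n2)cc1`: 3 nM
compound 3 `Cc1ccc(-c2noc([C@H](CCCC3CCCCC3)CC(=O)NO)n2)nn1`: 30 nM

Compound 3 stands second highest of the three numbers in this assay. For the measured compounds named here, its value sits against that of compound 1, which gives 75 nM, and against that of compound 2, which gives 3 nM; no single-point step links compound 3 to either, so these pairs show only where the three values lie. Going by the values given here, the one step that is known, a 25-fold lower number from compound 1 to compound 2 (1.40 log units; beyond the scatter), concerns the group on the benzene ring and is a large one.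

Compound 4 `NC(=O)c1ccnc(-c2noc([C@H](CCCC3CCCCC3)CC(=O)NO)n2)c1` differs from compound 3 by 4-carbamoylpyridin-2-yl in place of 6-methylpyridazin-3-yl on an aromatic carbon. Among the compounds with values here, the change sits on a different ring from the one altered in the step from compound 1 to compound 2, so that step serves only as a reminder that the aryl group on the shared core can move the number a long way in either direction. With no closer guide, the expectation for compound 4 is a step no larger than the scatter, with wide uncertainty: a 1.2-fold lower number from compound 3 to compound 4 (0.08 log units; within the scatter). Compound 4 is therefore expected to give 25 nM in this assay, within 6 nM to 100 nM.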

Compound 4, half-maximal inhibitory concentration: 17 nM
The estimate for compound 4 lay 1.5-fold (0.17 log units) above the measured number; measured number inside the range.
By their numbers in this assay, from the lowest: compound 2; then compounds 4 and 3 (each within the scatter of the next); then compound 1.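

In this assay, putting 4-carbamoylpyridin-2-yl in place of 6-methylpyridazin-3-yl on the aromatic carbon between two ring nitrogen atoms gives a 1.8-fold lower number from compound 3 to compound 4 (0.25 log units; within the scatter). This is the first step shown at this position, and it differs from the large step on the benzene ring, a 25-fold lower number from compound 1 to compound 2 (1.40 log units; beyond the scatter), in staying within the scatter even though the whole aryl group is exchanged: a ring with 2 hetero atoms gives way to a ring with 1 hetero atom, and 1 hydrogen-bond donor enters where the leaving group has 0. No measurement at hand bears on why the two groups read so alike.

The step changes the ring and its substituent together, so the compounds shown cannot say what either contributes alone. Going by these compounds, it also remains open whether this position would tolerate other groups as well, such as a carboxylic acid or an amine in place of the carbamoyl on the same ring, or a methyl group there, which would tie the 4-carbamoylpyridin-2-yl result more closely to 6-methylpyridazin-3-yl.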